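Shifting a bromo group: what to expect for compound 4

The source may hold more compounds than are shown below. What is called first, only, known or untested is meant among the compounds shown, and "the series" means these compounds.

In a functional assay on BT-20 cells (Homo sapiens) for cytotoxicity, read by MTT assay, with a stated time of 68 h (a lower number here means a stronger inhibitor, a higher number a weaker inhibitor), compound 2 `O=C(/C=C/c1cccc(OCc2ccccc2)c1)c1ccc(Br)cc1` gives 7400 nM. With hydroxy where compound 2 has bromo, compound 1 `O=C(/C=C/c1cccc(OCc2ccccc2)c1)c1ccc(O)cc1` gives 5100 nM. These two values cannot be told apart, as a 1.5-fold higher number from compound 1 to compound 2 (0.16 log units; within the scatter) shows. Compound 3 `O=C(/C=C/c1cccc(OCc2ccccc2)c1)c1ccccc1`, with hydrogen in that place, gives 25500 nM, a clearly higher number.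

Compound 4 `O=C(/C=C/c1cccc(OCc2ccccc2)c1)c1cccc(Br)c1` has the same atoms as compound 2, joined differently: 3-bromophenyl in place of 4-bromophenyl on a carbonyl carbon. Going by the values given here, no measured pair shows a bromo group changing place, so the data offer only an indirect guide. The nearest is a 3.4-fold higher number from compound 2 to compound 3 (0.54 log units; beyond the scatter), a modest step seen when the bromo group is lost altogether. Compound 4 keeps its bromo group, so a smaller change than that seems likely, with a slight lean towards a higher number. The expected change is a 1.2-fold higher number from compound 2 to compound 4 (0.09 log units; within the scatter), which would not stand out from the scatter. For compound 4, the estimated value is 9000 nM, with an expected range of 3500 nM to 22000 nM.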

Compound 4, half-maximal inhibitory concentration: 7100 nM
Compound 4: middle estimate off by 1.3-fold (0.10 log units), on the high side; measured number inside the range.
By their numbers in this assay, from the lowest: compounds 1, 4 and 2 (each within the scatter of the next); then compound 3.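

In this assay the shift of bromo to 3-bromophenyl in place of 4-bromophenyl on a carbonyl carbon gives a 1.0-fold lower number from compound 2 to compound 4 (0.02 log units; within the scatter) and so makes no measurable difference between these two placements. The link with compound 3, which carries hydrogen in place of this bromo, gives a 3.6-fold lower number from compound 3 to compound 4 (0.56 log units; beyond the scatter) and shows that bromo in its new place stands clear of hydrogen, as it did in compound 2. Set against the hydroxy compound, the step is a 1.4-fold higher number from compound 1 to compound 4 (0.14 log units; within the scatter), so 3-bromophenyl and 4-hydroxyphenyl cannot be told apart in this assay.

As far as these compounds go, whether an amine or a carboxylic acid on this ring would match bromo and hydroxy stays open. Nothing measured here bears on the reason for these results.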